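The source may hold more compounds than are shown below. What is called first, only, known or untested is meant among the compounds shown, and "the series" means these compounds.

Measured compounds in a functional assay on SiHa cells (Homo sapiens) for inhibition, read by MTT assay; a higher number here means a weaker inhibitor, a lower number a stronger inhibitor:
- compound 1 `CC1(C)C2CCC1(C)C(OC(=O)/C=C/c1ccc(O)c(O)c1[N+](=O)[O-])C2`: 51800 nM
- compound 2 `O=C(/C=C/c1cc(O)c(O)c([N+](=O)[O-])c1)OCCc1ccccc1`: "not determined" (no result reported)
- compound 3 `CC1(C)C2CCC1(C)C(OC(=O)/C=C/c1ccc(O)c(O)c1)C2`: 73700 nM

Compound 2 has no place on this scale, since no result was reported for it. Any comparison that starts from compound 2 therefore has no number to start from. The next compound to be tested is compound 4 `O=C(/C=C/c1cc(O)c(O)c(Br)c1)OCCc1ccccc1`, which has bromo in place of nitro on an aromatic carbon.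

Within the data shown here, only one measured step bears on this change: a 1.4-fold higher number from compound 1 to compound 3 (0.15 log units; within the scatter). There, hydrogen takes the place of nitro, and the step stays within the scatter. It is only a loose guide. Among the measured compounds shown here, no measured compound carries bromo, and neither compound in that step shares the core of compound 2. Losing the nitro group in that one case gave no real shift, so no step beyond the scatter is expected in this assay, and no direction can be given. The best available anchors are compound 1 at 51800 nM and compound 3 at 73700 nM, and the range is kept wide to reflect the different core.

For compound 4 the expected value is 50000 nM, with an estimated range from 15000 nM to 130000 nM.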

Compound 4, half-maximal inhibitory concentration: 28500 nM
Compound 4: middle estimate off by 1.8-fold (0.24 log units), on the high side; low and high end bracket the measured number.
By their numbers in this assay, from the lowest: compounds 4, 1 and 3 (each within the scatter of the next, the first and the last beyond it).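

In this assay, among these compounds, compound 4 gives 28500 nM and compound 2, the only compound differing from it in one place, has no number, so no new step can be read. No measured evidence bears on this result. The compounds shown leave open how bromo compares with nitro on the core of compound 2.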